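A few compounds are considered here, and "the series" means these few. Any claim that something is new, unique, unknown or untested is made for them only; others in the source may bear on it.

Compound 2, `O=C(Nc1cccnc1)c1c(O)c2cccnc2n(-c2ccccc2)c1=O`, in a functional assay on the whole organism for inhibition, with Rattus norvegicus as the target, read by paw edema, at a dose of 100 mg/kg by the oral route (on this read-out lower numbers stand for less inhibition and higher numbers for more inhibition at the one dose given (going by the name of the read-out)), gives 30.3% and stands at the top of the two numbers recorded so far. Its nearest neighbour is compound 1, `COc1cccc(NC(=O)c2c(O)c3cccnc3n(-c3ccccc3)c2=O)c1`, which in this assay gives 5.7%. Among the measured compounds shown here, the one measured step, a number 24.6 percentage points higher from compound 1 to compound 2 (beyond the scatter), shows that exchanging the amide-side aryl group moved the read-out by a modest amount beyond the scatter.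

Compound 3, `O=C(Nc1ccc(Cl)nc1)c1c(O)c2cccnc2n(-c2ccccc2)c1=O`, differs from compound 2 only in this: chloro in place of hydrogen on an aromatic carbon. For the measured compounds named here, no measured step concerns a substituent placed on this pyridin-3-yl ring; the single step recorded concerns the whole aryl group on the amide-type nitrogen, so it bears on the present change only loosely, as a sign that this part of the molecule can shift the read-out by a modest amount. Going by the values given here, with no direct precedent, the change from compound 2 to compound 3 is expected to give no step beyond the scatter, a number 0.3 percentage points lower from compound 2 to compound 3 (within the scatter). Compound 3 is therefore estimated at 30%, within a range from 12% to 50%.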

Compound 3, a percentage reported as inhibition, in the whole organism at one dose (the size of the read-out at that dose, not a potency): 9.2%
Compound 3: the middle estimate sits 20.8 percentage points above what was measured; the measured number lies below the stated range.
By their numbers in this assay, from the lowest: compounds 1 and 3 (each within the scatter of the next); then compound 2.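

In this assay, a single chloro on the pyridin-3-yl ring, on the aromatic carbon next to the ring nitrogen and para to a large group, changes the read-out beyond the scatter: a number 21.1 percentage points lower from compound 2 to compound 3 (beyond the scatter). The earlier step, a number 24.6 percentage points higher from compound 1 to compound 2 (beyond the scatter), came from exchanging the whole group on the amide-type nitrogen, whereas this modest step comes from one added heavy atom, so this ring position also affects the read-out. The gain seen with pyridin-3-yl does not carry over to 6-chloropyridin-3-yl, as a number 3.5 percentage points higher from compound 1 to compound 3 (within the scatter) leaves those two compounds within the scatter of each other, and no available evidence accounts for the effect of the chloro.

The compounds shown leave open whether this drop belongs to chloro in particular or would also follow from fluoro, methyl or an amine on the same carbon, and whether chloro on another carbon of the ring would act in the same way. They also leave open whether the gap between these compounds would hold at other doses, since each number comes from a single oral dose.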